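Dropping the Hydroxy Group: From Compound 1 to Compound 4

The source may report more compounds than this note shows. Statements on the series, on what has been measured and on what is new or still open speak of the compounds shown alone.

Three compounds have been measured in a functional assay (muscle tissue) with Cavia porcellus as the target; on this read-out higher numbers stand for an effect only at larger amounts of compound and lower numbers for an effect already at smaller amounts:

Compound 1 `COC(=O)C1=C(C)N=C(C)/C(=C(\O)OC)C1c1cc([N+](=O)[O-])ccc1O` gives 100 nM
Compound 2 `C=Cc1ccccc1C1C(C(=O)OC)=C(C)N=C(C)/C1=C(\O)OC` gives 4.47 nM
Compound 3 `COC(=O)C1=C(C)N=C(C)/C(=C(\O)OC)C1c1cccc(Cl)c1Cl` gives 19.1 nM

Compound 1 stands highest of the three; compound 3 is nearest and compound 2 furthest, both beyond the scatter. For the measured compounds named here, the only measured single step, a 4.3-fold higher number from compound 2 to compound 3 (0.63 log units; beyond the scatter), swaps one aryl group for another and does not touch a hydroxy group. Compound 4 `COC(=O)C1=C(C)N=C(C)/C(=C(\O)OC)C1c1cccc([N+](=O)[O-])c1` differs from compound 1 as follows: hydrogen in place of hydroxy on an aromatic carbon. Going by the values given here, no measured step bears directly on this change. Both compounds without a hydroxy on that ring, compound 2 and compound 3, show lower numbers than compound 1, but they differ in other places too, so the guidance is weak. A lower number is nonetheless expected for compound 4, namely a 4.0-fold lower number from compound 1 to compound 4 (0.60 log units; beyond the scatter), with an estimate of 25 nM and a range from 5 nM to 120 nM.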

Compound 4, half-maximal effective concentration: 3.98 nM
The estimate for compound 4 lay 6.3-fold (0.80 log units) above the measured number; measured number outside the range, below it.
By their numbers in this assay, from the lowest: compounds 4 and 2 (each within the scatter of the next); then compound 3; then compound 1.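

In this assay, for the compounds shown here, the change gives a 25-fold lower number from compound 1 to compound 4 (1.40 log units; beyond the scatter) and so offers the first direct reading of this position. Here, ortho to a large group and para to a nitro group, compound 1 with its hydroxy group needs far more compound for an effect than compound 4 with hydrogen. Nothing available explains why this step is so large.

As far as these compounds go, whether a methoxy group or an amine at this position would behave more like hydroxy or like hydrogen stays open. So does whether the step would hold without the nitro group.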